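This account rests on a few compounds, and the source may have more. Where it says the series, first, only, none or still open, it means among the compounds named here.

Compound 2, `COc1cccc(C(=O)Nc2cccc(-c3oc4cc(-c5ccc(F)cc5)ccc4c(=O)c3O)c2)c1`, is measured in a functional assay on A549 cells (Homo sapiens) for antiproliferative activity, read by CCK-8 assay, with a stated time of 72 h (a higher number here means a weaker inhibitor, a lower number a stronger inhibitor), at 10800 nM. On the numbers in hand it has the highest value of the three compounds, but its nearest neighbour is compound 1, `COc1ccc(C(=O)Nc2cccc(-c3oc4cc(-c5ccc(F)cc5)ccc4c(=O)c3O)c2)cc1`, which gives 8700 nM, and its furthest is compound 3, `O=C(Nc1cccc(-c2oc3cc(-c4ccc(F)cc4)ccc3c(=O)c2O)c1)c1cc(F)cc(F)c1`, which gives 7620 nM. Both gaps lie within the scatter of repeated measurements: the step from compound 1 to compound 2 reads a 1.2-fold higher number from compound 1 to compound 2 (0.09 log units; within the scatter), and the step from compound 2 to compound 3 reads a 1.4-fold lower number from compound 2 to compound 3 (0.15 log units; within the scatter). The remaining step, a 1.1-fold lower number from compound 1 to compound 3 (0.06 log units; within the scatter), is likewise within the scatter.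

Compound 4 is `N#Cc1ccc(C(=O)Nc2cccc(-c3oc4cc(-c5ccc(F)cc5)ccc4c(=O)c3O)c2)cc1`. It differs from compound 2 in one place: 4-cyanophenyl in place of 3-methoxyphenyl on a carbonyl carbon. This is the same kind of change that separates the three measured compounds, each of which carries a different aryl group on the carbonyl carbon, and none of those exchanges moved the value beyond the scatter. The step from compound 2 to compound 4 is therefore expected to be a 1.2-fold lower number from compound 2 to compound 4 (0.08 log units; within the scatter), with no direction beyond the scatter. Compound 4 is estimated at 9000 nM in this assay, with a range from 4000 nM to 20000 nM.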

Compound 4, half-maximal inhibitory concentration: 2360 nM
For compound 4 the middle estimate is 3.8-fold (0.58 log units) above the measured one; measured number below the stated range.
By their numbers in this assay, from the lowest: compound 4; then compounds 3, 1 and 2 (each within the scatter of the next).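

In this assay, the aryl group on the carbonyl carbon proves able to move the value: the three earlier aryl groups stayed within the scatter of one another, whereas 4-cyanophenyl gives a 4.6-fold lower number from compound 2 to compound 4 (0.66 log units; beyond the scatter) and, set against the 3,5-difluorophenyl group, a 3.2-fold lower number from compound 3 to compound 4 (0.51 log units; beyond the scatter). The closest comparison is cyano in place of methoxy on an aromatic carbon, which gives a 3.7-fold lower number from compound 1 to compound 4 (0.57 log units; beyond the scatter), so exchanging that one group on the 4-substituted phenyl is enough to separate compound 4 from the rest, and compound 4 is the most potent of the four, though the steps remain modest. Nothing available explains why this exchange, alone among those seen, goes beyond the scatter.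

The compounds shown leave open whether the change is specific to the nitrile, as only compound 4 carries one, and a trifluoromethyl, a carboxylic acid or an amine on that aromatic carbon would test this. They also leave open whether the same step would appear on a different core.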